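Benzyl replacing 3-methoxyphenyl at the saturated ring carbon

This account rests on a few compounds, and the source may have more. Where it says the series, first, only, none or still open, it means among the compounds named here.

Of the compounds shown here, two have been measured in an assay on Sf9 cells for inhibition of serine/threonine-protein kinase 4 (Homo sapiens), read by luminescence and ADP-Glo, with a stated time of 1 h, in the presence of a further agent that is not named here; on this read-out higher numbers stand for weaker inhibition and lower numbers for stronger inhibition. Compound 1 `CN1C(=O)C(c2cccc(F)c2)N(C)c2nc(Nc3ccc(S(N)(=O)=O)cc3)ncc21` gives 134 nM in this assay. Among the compounds with values here, compound 2 `COc1cccc(C2C(=O)N(C)c3cnc(Nc4ccc(S(N)(=O)=O)cc4)nc3N2C)c1` gives 954 nM in this assay, which is the highest of the two numbers; its nearest neighbour is compound 1, and the only step recorded is a 7.1-fold higher number from compound 1 to compound 2 (0.85 log units; beyond the scatter). Compound 3 `CN1C(=O)C(Cc2ccccc2)N(C)c2nc(Nc3ccc(S(N)(=O)=O)cc3)ncc21` has not yet been measured in this assay. It differs from compound 2 in one place: benzyl in place of 3-methoxyphenyl on a saturated ring carbon. Within the data shown here, no measured step covers a change of this kind; the step from compound 1 to compound 2 concerns only the group on the aromatic ring and shows that what sits at this position can move the number by a modest amount. The new change is larger in kind, so a step of similar or larger size is possible in either direction, and the direction cannot be read from the two compounds in hand. Compound 3 is therefore expected to give about 500 nM in this assay, within a range of 120 nM to 2000 nM. This estimate means a step of a 1.9-fold lower number from compound 2 to compound 3 (0.28 log units; within the scatter), and it is an expectation rather than a measurement.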

Compound 3, half-maximal inhibitory concentration: > 10000 nM
Compound 3 was reported as a limit; the forecaster's own chance of this, stated with the estimate: 5%; at least 20-fold (1.30 log units) between middle value and limit.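

Compound 3 is reported only as a limit in this assay: the limit of > 10000 nM in this assay, at which 1 of the 3 values shown sits. Benzyl in place of an aromatic ring bearing a fluoro or methoxy group gives steps of a different order at this saturated ring carbon: an at least 10-fold higher number from compound 2 to compound 3 (1.02 log units; beyond the scatter), and an at least 74-fold higher number from compound 1 to compound 3 (1.87 log units; beyond the scatter). Within the data shown here, the earlier pair showed only that the group on the aromatic ring can shift the number, as in a 7.1-fold higher number from compound 1 to compound 2 (0.85 log units; beyond the scatter), whereas this result shows that changing the whole group on the saturated ring carbon can take inhibition out of the range the assay reads, and both new steps are minimum sizes rather than exact ones.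

The compounds shown leave open whether the loss goes with benzyl as such or with the absence of a fluoro or methoxy group on its aromatic ring, a question that an unsubstituted phenyl at this carbon, or a benzyl carrying 3-fluoro or 3-methoxy, would address. They also say nothing about how a longer chain such as 2-phenylethyl, or a group with an amine or a carboxylic acid, would behave at this carbon.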